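The source may report more compounds than this note shows. Statements on the series, on what has been measured and on what is new or still open speak of the compounds shown alone.

Compound 2 `Cc1cc(O)c(C2=NN(c3ccc(S(N)(=O)=O)cc3)C(/C=C/c3ccccc3)C2)cc1Cl` carries a 2-phenylethenyl group on a saturated ring carbon of its core. For the measured compounds named here, in a functional assay on MOLT-4 cells (Homo sapiens) for antiproliferative activity, with a stated time of 48 h (on this read-out lower numbers stand for stronger inhibition of growth and higher numbers for weaker inhibition of growth), compound 2 gives 73700 nM, the lowest of the two numbers so far, although the gap to its only neighbour lies within the scatter. That neighbour, compound 1 `Cc1cc(O)c(C2=NN(c3ccc(S(N)(=O)=O)cc3)C(c3ccccc3Cl)C2)cc1Cl`, gives in this assay 100000 nM. Going by the values given here, the single measured step, a 1.4-fold lower number from compound 1 to compound 2 (0.13 log units; within the scatter), is too small to separate the two compounds. Compound 3 `COc1ccc(C2CC(c3cc(Cl)c(C)cc3O)=NN2c2ccc(S(N)(=O)=O)cc2)c(OC)c1OC` differs from compound 2 by 2,3,4-trimethoxyphenyl in place of 2-phenylethenyl on a saturated ring carbon. Among the compounds with values here, the only step that bears on this change is the earlier exchange at the same saturated ring carbon, a 1.4-fold lower number from compound 1 to compound 2 (0.13 log units; within the scatter), and no value exists for a trimethoxyphenyl group in this position. Compound 3 is therefore expected to stay in the same weak range, with an estimated step of a 1.2-fold lower number from compound 2 to compound 3 (0.09 log units; within the scatter) that need not exceed the scatter. The estimate for compound 3 in this assay is 60000 nM, between 20000 nM and 150000 nM.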

Compound 3, concentration for total growth inhibition: 100000 nM
Compound 3: middle estimate off by 1.7-fold (0.22 log units), on the low side, within the range that was stated.
By their numbers in this assay, from the lowest: compounds 2, 1 and 3 (each within the scatter of the next).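

Exchanging 2-phenylethenyl for 2,3,4-trimethoxyphenyl on the saturated ring carbon gives a 1.4-fold higher number from compound 2 to compound 3 (0.13 log units; within the scatter) in this assay even though the entering group has more heavy atoms and brings 3 hydrogen-bond acceptors. Exchanging 2-chlorophenyl for the same 2,3,4-trimethoxyphenyl group gives no change at the digits printed from compound 1 to compound 3 (within the scatter) and so leaves the number unchanged at the digits printed. Across these three compounds, then, the choice among the three groups at this position cannot be told apart from the scatter, and no information is available to explain this result.

The compounds shown leave open whether a group of another kind on this carbon, such as an amine, a carboxylic acid or a longer alkyl chain, would move the number beyond the scatter. They also leave open whether changes elsewhere on the shared core would do so.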